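A few compounds are considered here, and "the series" means these few. Any claim that something is new, unique, unknown or untested is made for them only; others in the source may bear on it.

Compound 2 `CC(=O)N1CCC(C(=O)N(CCCN2CCN(Cc3cccnc3)CC2)c2ccc(C)c(Cl)c2)CC1` is known in an ADME assay (Homo sapiens) for cytotoxicity (a higher number here means that more compound is tolerated, a lower number that less compound is tolerated), only as a limit: compound 2 gives > 56700 nM. Compound 1 `CC(=O)N1CCC(C(=O)N(CCCN2CCC(CNC(=O)c3cnccn3)CC2)c2ccc(C)c(Cl)c2)CC1` likewise reaches a limit in this assay, at > 52400 nM. Compound 3 `CC(=O)N1CCC(C(=O)N(CCCN2CCN(Cc3ccncc3)CC2)c2ccc(C)c(Cl)c2)CC1` also ends at a limit, with > 56700 nM. The single one-place step among these, a step that the two limits leave unreadable from compound 2 to compound 3, stays unreadable because the limit of > 56700 nM in this assay, at which 2 of the 3 values shown sit, caps both of its ends. Among the compounds with values here, the whole set thus shows only the limit of > 52400 nM in this assay, at which 1 of the 3 values shown sits, and (the limit of > 56700 nM in this assay, at which 2 of the 3 values shown sit), with no step readable anywhere. Compound 4 `CC(=O)N1CCC(C(=O)N(CCCN2CCN(Cc3ccc(C(F)(F)F)cc3)CC2)c2ccc(C)c(Cl)c2)CC1` differs from compound 2 by 4-(trifluoromethyl)phenyl in place of pyridin-3-yl on a saturated chain carbon bound to an amine nitrogen in a ring. Within the data shown here, no measured step bears on this change, so compound 4 is expected to remain near the same ceiling, an estimated at least 1.1-fold lower number from compound 2 to compound 4 (0.05 log units; that floor lies within the scatter). Compound 4 is therefore estimated at 50000 nM, with a range from 20000 nM to 100000 nM.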

Compound 4, half-maximal cytotoxic concentration: 30500 nM
The estimate for compound 4 lay 1.6-fold (0.21 log units) above the measured number; measured number inside the range.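

Within the data shown here, at the place on a saturated chain carbon bound to an amine nitrogen in a ring, compound 4 gives the first number in this assay that is not a limit. Its 4-(trifluoromethyl)phenyl group gives an at least 1.8-fold lower number from compound 2 to compound 4 (0.26 log units; that floor lies within the scatter) and an at least 1.8-fold lower number from compound 3 to compound 4 (0.26 log units; that floor lies within the scatter). These steps remain floors because compound 2 and compound 3 each end at a limit: the limit of > 56700 nM in this assay, at which 2 of the 4 values shown sit.

From the compounds shown here alone, whether the real gap goes beyond the scatter stays open. So does whether an unsubstituted phenyl or a 4-carboxyphenyl group at this place would give a number or a limit.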